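The compounds below may be only part of what the source reports. "The series", "measured", "known", "first", "only" and "open" are said of these compounds alone.

Measured so far:
- compound 1, `CCCS(=O)(=O)N1CCC(CNC(=O)c2c(F)cccc2F)(C(=O)N2CCOCC2)CC1`: "not determined" (no result reported)
- compound 2, `CCCS(=O)(=O)N1CCC(CNC(=O)c2c(F)ccc(Cl)c2F)(C(=O)N2CCOCC2)CC1`: 19.7 nM
- compound 3, `CCCS(=O)(=O)N1CCC(CNC(=O)c2ccccc2OC(F)(F)F)(C(=O)N2CCOCC2)CC1`: "not determined" (no result reported)

Among the measured compounds shown here, in an assay on isolated protein for inhibition of sodium- and chloride-dependent glycine transporter 1 (Rattus norvegicus) (on this read-out lower numbers stand for stronger inhibition and higher numbers for weaker inhibition), compound 2 gives 19.7 nM and is the only member of the series with a number. Compound 3 stands without a single number; compound 1 is the one further entry without a number, so nothing can be said about how compound 3 compares. Compound 4, `CCCS(=O)(=O)N1CCC(CNC(=O)c2ccccc2Cl)(C(=O)N2CCOCC2)CC1`, is to be measured in this assay. It differs from compound 3 by chloro in place of trifluoromethoxy on an aromatic carbon. With no step between measured compounds shown, the size of the change on this assay is open; a move of the order of the usual scatter in either direction is expected rather than a large one. Compound 4 is expected to give about 40 nM, in the range 10 nM to 160 nM.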

Compound 4, half-maximal inhibitory concentration: 18.3 nM
Beside the measured number, compound 4's estimate is 2.2-fold (0.34 log units) above it; the measured number falls inside the stated range.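

In this assay the series now has one readable step, a 1.1-fold lower number from compound 2 to compound 4 (0.03 log units; within the scatter), with 2-chlorophenyl in place of 3-chloro-2,6-difluorophenyl on the carbonyl carbon. A lone chloro group on the aromatic ring, without the two fluoro groups, therefore keeps the read-out within the scatter of the more heavily substituted ring. Nothing shown explains this result.

The steps involving compound 1 and compound 3 cannot be read, so the change from 2-(trifluoromethoxy)phenyl to 2-chlorophenyl has no size. Going by these compounds, how an amine or a carboxylic acid would fare at this aromatic carbon remains open.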